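Piperidinyl for propylsulfanyl in an acylguanidine series

A few compounds are considered here, and "the series" means these few. Any claim that something is new, unique, unknown or untested is made for them only; others in the source may bear on it.

Compound 1, `Cc1c(C(=O)N=C(N)N)cc(S(C)(=O)=O)c(Cl)c1[N+](=O)[O-]`: 44 nM
Compound 2, `CCCSc1cc(C)c(C(=O)N=C(N)N)cc1S(C)(=O)=O`: 6.8 nM
Compound 3, `Cc1c(C(=O)N=C(N)N)ccc(Oc2cccnc2)c1S(C)(=O)=O`: 2200 nM

In a functional assay for inhibition of sodium/hydrogen exchanger (Oryctolagus cuniculus) (a lower number here means a stronger inhibitor, a higher number a weaker inhibitor), compound 2 gives the lowest of the three numbers; its gap to compound 1 and its far larger gap to compound 3 both lie beyond the scatter of repeated measurements, so compound 2 is the strongest inhibitor among the measured compounds. Compound 4, `Cc1cc(N2CCCCC2)c(S(C)(=O)=O)cc1C(=O)N=C(N)N`, is not yet measured. It differs from compound 2 in a single place: piperidin-1-yl in place of propylsulfanyl on an aromatic carbon. Going by the values given here, no measured pair shows this exchange, so the size of the step is open. A piperidin-1-yl group is expected to cost little, and the step of a 2.2-fold higher number from compound 2 to compound 4 (0.34 log units; beyond the scatter) in this assay is estimated to be small, toward a weaker inhibitor and near the edge of the scatter. Compound 4 is therefore expected to give about 15 nM in this assay, within a range from 4 nM to 60 nM.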

Compound 4, half-maximal inhibitory concentration: 21 nM
The estimate for compound 4 lay 1.4-fold (0.15 log units) below the measured number, and the stated range covers the measured number.
By their numbers in this assay, from the lowest: compound 2; then compound 4; then compound 1; then compound 3.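

In this assay the exchange of propylsulfanyl for piperidin-1-yl gives a 3.1-fold higher number from compound 2 to compound 4 (0.49 log units; beyond the scatter) and this modest step shows that the position, ortho to a methylsulfonyl group, accepts a six-membered non-aromatic ring on nitrogen in place of an open chain on sulfur, at a measurable but limited cost. Nothing available explains the size of this step. Still open, as far as these compounds go, is how a pyrrolidin-1-yl ring, a morpholin-4-yl ring or an open-chain dimethylamino group would fare at this position. Also open, from the compounds shown here alone, is whether a longer chain on sulfur would move the number in either direction.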